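The compounds below may be only part of what the source reports. "The series", "measured", "known", "first", "only" and "open" are said of these compounds alone.

In a functional assay on a cell-free system (Platelet, plasma, Homo sapiens) for inhibition (on this read-out lower numbers stand for stronger inhibition and higher numbers for weaker inhibition), three compounds sharing one core have been measured. Compound 1 `COc1ccc(C(=O)N(CCN2CCC(OCC(=O)O)CC2)c2ccc(C)cc2)cc1`, with 4-methoxyphenyl on the carbonyl carbon, gives 1200 nM. Compound 2 `Cc1ccc(N(CCN2CCC(OCC(=O)O)CC2)C(=O)c2cccc(C)c2)cc1`, with 3-methylphenyl there, gives 160 nM. Compound 3 `COc1cccc(C(=O)N(CCN2CCC(OCC(=O)O)CC2)c2ccc(C)cc2)c1`, with 3-methoxyphenyl there, gives 32 nM, the lowest number of the three, with both others beyond the scatter from it.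

Compound 4 `COc1ccc(C(=O)N(CCN2CCC(OCC(=O)O)CC2)c2ccc(C)cc2)cc1OC` departs from compound 3 by one change: methoxy in place of hydrogen on an aromatic carbon, which turns 3-methoxyphenyl into 3,4-dimethoxyphenyl. This group holds the methoxy of 3-methoxyphenyl and also that of 4-methoxyphenyl. The closest evidence is the large step of a 38-fold lower number from compound 1 to compound 3 (1.57 log units; beyond the scatter). The modest steps of a 7.5-fold lower number from compound 1 to compound 2 (0.88 log units; beyond the scatter) and a 5.0-fold lower number from compound 2 to compound 3 (0.70 log units; beyond the scatter) also leave compound 1 with the highest number. Going by the values given here, no measured compound carries both methoxy groups, so their combined outcome is untested. A modest move to a higher number in this assay is therefore expected, a 4.7-fold higher number from compound 3 to compound 4 (0.67 log units; beyond the scatter). For compound 4 the estimated value is 150 nM, with an expected range of 40 nM to 600 nM.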

Compound 4, half-maximal inhibitory concentration: > 3000 nM
Compound 4 was reported as a limit; the forecaster's own chance of this, stated with the estimate: 3%; middle value at least 20-fold (1.30 log units) away from the limit.
By their numbers in this assay, from the lowest: compound 3; then compound 2; then compound 1. At a limit, above all of these: compound 4.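

In this assay compound 4 sits at a limit of the assay and not at a number, so its steps give only a minimum size: the limit of > 3000 nM in this assay, at which 1 of the 4 values shown sits. Methoxy on this carbon, ortho to a methoxy group and para to a large group, removes the advantage of 3-methoxyphenyl, with an at least 93-fold higher number from compound 3 to compound 4 (1.97 log units; beyond the scatter), and the 3,4-dimethoxyphenyl group also compares poorly with 3-methylphenyl, with an at least 18-fold higher number from compound 2 to compound 4 (1.27 log units; beyond the scatter). The earlier compounds shown here could not show that the methoxy of 3-methoxyphenyl fails to offset a methoxy at this position, but an at least 2.5-fold higher number from compound 1 to compound 4 (0.39 log units; beyond the scatter) brings no lowering, and compound 1 and compound 4, the two compounds with methoxy here, hold the highest numbers.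

The compounds shown leave open whether a fluorine atom, a hydroxyl or a methyl on this carbon would behave like methoxy. Going by these compounds, the actual value of compound 4 also stays open.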